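Adding a Second Chloro Group: From Compound 2 to Compound 4

The source may report more compounds than this note shows. Statements on the series, on what has been measured and on what is new or still open speak of the compounds shown alone.

Of the compounds shown here, three built on the same fused two-ring core have been tested in a functional assay on HOP-62 cells (Homo sapiens) for cytotoxicity, read by sulforhodamine B assay, with a stated time of 48 h; on this read-out higher numbers stand for lower toxicity in this test and lower numbers for higher toxicity in this test. Compound 1 `ClCc1ccccc1Cn1cnc2c(Cl)nc(Cl)nc21` gives 6450 nM. Compound 2 `ClCc1ccccc1Cn1cnc2ncnc(Cl)c21` gives 75900 nM. Compound 3 `Nc1nc(Cl)c2ncn(Cc3cccc(CCl)c3)c2n1` gives 58900 nM. Among these three numbers compound 2 stands at the top; its value sits within the scatter of that of compound 3, but far apart from that of compound 1, which carries two chloro groups on the six-membered aromatic ring of the core and is clearly more toxic in this test.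

Compound 4 `ClCc1ccccc1Cn1cnc2nc(Cl)nc(Cl)c21` has not yet been measured. It differs from compound 2 by chloro in place of hydrogen on an aromatic carbon, so that compound 4, like compound 1, carries two chloro groups on that ring. For the measured compounds named here, no pair of measured compounds isolates exactly this change. Still, compound 1 with its two chloro groups gives 6450 nM, while compound 2 with one gives 75900 nM. The step from compound 2 to compound 4 in this assay is therefore expected to lower the number beyond the scatter, a 5.1-fold lower number from compound 2 to compound 4 (0.70 log units; beyond the scatter). Compound 4 is estimated to give about 15000 nM, with a likely range from 4000 nM to 60000 nM.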

Compound 4, concentration lethal to 50% of the cells: 16600 nM
For compound 4 the middle estimate is 1.1-fold (0.04 log units) below the measured one, within the range that was stated.
By their numbers in this assay, from the lowest: compound 1; then compound 4; then compounds 3 and 2 (each within the scatter of the next).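

In this assay, for the compounds shown here, chloro in place of hydrogen on the aromatic carbon between two ring nitrogen atoms gives a 4.6-fold lower number from compound 2 to compound 4 (0.66 log units; beyond the scatter), the first reading of a single change at this position. The step lies beyond the scatter, so one added chlorine atom at this place is enough to shift the result clearly towards higher toxicity in this test. Nothing available explains why the number moves in this way. From the compounds shown here alone, whether a different group on this carbon, such as methoxy or fluoro, would lower the number as well, leave it unchanged or raise it remains open. Also open, going by these compounds, is whether the same step would appear in cell types other than those tested here.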